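The source may hold more compounds than are shown below. What is called first, only, known or untested is meant among the compounds shown, and "the series" means these compounds.

Measured so far in a physicochemical assay for lipophilicity; on this read-out lower numbers stand for lower lipophilicity and higher numbers for higher lipophilicity:

- compound 1 (`CCCc1nc2cc(C)c(C)cc2[nH]1`) gives 3.4
- compound 2 (`CCCCc1nc2cc(C)c(C)cc2[nH]1`) gives 3.9

Compound 2, at 3.9, holds the higher of the two numbers. The next step leads from it to compound 3 (`CCCCCCCc1nc2cc(C)c(C)cc2[nH]1`), which has not yet been measured. The structural change is propyl in place of hydrogen on a saturated chain carbon, four bonds along the chain from an aromatic carbon, in words propyl in place of hydrogen on a saturated chain carbon, four bonds along the chain from an aromatic carbon.

Within the data shown here, only one measured step bears on this change, and it is modest but beyond the scatter: a number 0.50 log units higher from compound 1 to compound 2 (beyond the scatter), with methyl in place of hydrogen on the chain. Propyl is the bigger group, so a rise in this assay is expected again, and one clearly larger than that single step. One step is thin evidence, however, and nothing measured yet shows how far such a rise carries along a longer chain.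

The expected step is a number 1.50 log units higher from compound 2 to compound 3 (beyond the scatter). Compound 3 is therefore estimated at 5.4, with an expected range from 4.8 to 5.9.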

Compound 3, partition coefficient: 5.4
The estimate for compound 3 equals the measured number at the digits printed, and the stated range covers the measured number.
By their numbers in this assay, from the lowest: compound 1; then compound 2; then compound 3.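

In this assay the position takes a much larger group and the number goes on climbing, with a number 1.50 log units higher from compound 2 to compound 3 (beyond the scatter) for the propyl change, so the rise seen for methyl does not stop at that first addition. Spread evenly over its 3 carbon atoms, the propyl step comes to the same size per carbon as the methyl step, a number 0.50 log units higher from compound 1 to compound 2 (beyond the scatter), and the three compounds together run in one direction without any sign of levelling off, with a number 2.00 log units higher from compound 1 to compound 3 (beyond the scatter) across the whole series and no compound going against the trend. Nothing at hand explains why the number moves in this way, as no further evidence bears on the result.

The compounds shown leave open whether the same even rise continues on a still longer chain, and whether a branched chain such as isobutyl would match a straight chain with the same number of carbons. They also leave open how far the number would shift if a hydroxyl, an amine or a carboxylic acid stood at the end of the chain.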